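The compounds below may be only part of what the source reports. "The series", "measured", "known", "first", "only" and "open" are said of these compounds alone.

In a functional assay on MDA-MB-435 cells (Homo sapiens) for cytotoxicity, read by MTT assay, with a stated time of 72 h (a lower number here means a stronger inhibitor, a higher number a weaker inhibitor), compound 1 (`Nc1ccc(Nc2c(C(=O)NCc3ccc(F)cc3)nc(Br)c3cccnc23)cc1`) gives 7000 nM and compound 2 (`N[C@H]1CC[C@H](Nc2c(C(=O)NCc3ccc(Cl)cc3Cl)nc(Br)c3cccnc23)CC1`) gives 5800 nM. Compound 3 (`O=C(NCc1ccc(F)cc1)c1nc(Br)c2cccnc2c1NCCO`) reads > 20000 nM, which is a limit of the assay and not a number. That places it at the limit of > 20000 nM in this assay, at which 1 of the 3 values shown sits.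

Compound 4 (`O=C(NCc1ccc(F)cc1)c1nc(Br)c2cccnc2c1NCc1ccccc1`) keeps the core and the amide side of compound 3 but has phenyl in place of hydroxymethyl on a saturated chain carbon bound to a nitrogen on an aromatic ring, so 2-hydroxyethyl becomes benzyl: phenyl in place of hydroxymethyl on a saturated chain carbon bound to a nitrogen on an aromatic ring.

For the measured compounds named here, only one measured step bears on this change. It is an at least 2.8-fold higher number from compound 1 to compound 3 (0.45 log units; beyond the scatter), where 2-hydroxyethyl took the place of 4-aminophenyl. Compound 1, with its ring on that nitrogen, therefore holds the better guide, and a benzyl group also brings a ring back. The expected change is an at least 2.2-fold lower number from compound 3 to compound 4 (0.34 log units; beyond the scatter), towards a lower number, although this expectation rests on that single step. For compound 4 the estimated value in this assay is 9000 nM, with an expected range of 3000 nM to 25000 nM.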

Compound 4, half-maximal inhibitory concentration: > 20000 nM
Compound 4 was reported as a limit (the forecaster's own chance of this, stated with the estimate: 25%); middle value at least 2.2-fold (0.34 log units) from the limit.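

A ring on this nitrogen is not enough on its own in this assay: compound 4 has one in its benzyl group, yet it does not come back into the measurable range as compound 1 does. Benzyl in place of 4-aminophenyl gives an at least 2.8-fold higher number from compound 1 to compound 4 (0.45 log units; beyond the scatter), so the kind of group on that nitrogen matters, not merely the presence of a ring. The readings of compound 3 and compound 4 are both limits of the assay and not numbers, so the step between them cannot be read, and neither can any order of the two: the limit of > 20000 nM in this assay, at which 2 of the 4 values shown sit.

Compound 1 and compound 4 differ both in the amine on the ring and in the saturated chain carbon that holds the ring on the nitrogen. A 4-aminobenzyl or a plain phenyl group on that nitrogen would be needed to tell these two features apart.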